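A few compounds are considered here, and "the series" means these few. Any claim that something is new, unique, unknown or untested is made for them only; others in the source may bear on it.

Working notes on the series. The shared core is carried unchanged; the variation sits on an aromatic carbon ortho to a methylsulfonyl group and para to a group of 6 heavy atoms. Compound 1 `CS(=O)(=O)c1cc(C(=O)N=C(N)N)ccc1C#N` gives 140 nM in a functional assay for inhibition of sodium/hydrogen exchanger (Oryctolagus cuniculus); a lower number here means a stronger inhibitor, a higher number a weaker inhibitor. Compound 2 `CS(=O)(=O)c1cc(C(=O)N=C(N)N)ccc1Oc1cncc(Cl)c1` gives 75 nM in this assay, the lowest of the two numbers shown, though the step of a 1.9-fold lower number from compound 1 to compound 2 (0.27 log units; within the scatter) is within the scatter, so no order between compound 2 and compound 1 can be claimed. Compound 3 `CS(=O)(=O)c1cc(C(=O)N=C(N)N)ccc1N1CCC(N)CC1` carries 4-aminopiperidin-1-yl in place of (5-chloropyridin-3-yl)oxy on an aromatic carbon. Going by the values given here, only one measured step bears on this position, a 1.9-fold lower number from compound 1 to compound 2 (0.27 log units; within the scatter), and it was within the scatter; no step to a non-aromatic ring with a hydrogen-bond donor has been measured. For compound 3 the expected step of a 1.3-fold higher number from compound 2 to compound 3 (0.12 log units; within the scatter) is therefore none beyond the scatter, with wide uncertainty. Compound 3 is estimated at 100 nM, in the range 25 nM to 400 nM, in this assay.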

Compound 3, half-maximal inhibitory concentration: 160 nM
Beside the measured number, compound 3's estimate is 1.6-fold (0.20 log units) below it; the measured number falls inside the stated range.
By their numbers in this assay, from the lowest: compounds 2, 1 and 3 (each within the scatter of the next, the first and the last beyond it).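

In this assay, going by these compounds alone, the change to 4-aminopiperidin-1-yl gives a 2.1-fold higher number from compound 2 to compound 3 (0.33 log units; beyond the scatter) and is the first step at this position to lie beyond the scatter, if only modestly. Against cyano the same group gives a 1.1-fold higher number from compound 1 to compound 3 (0.06 log units; within the scatter) and so cannot be ordered, which means that a non-aromatic ring with a hydrogen-bond donor lies within the scatter of a nitrile here. Nothing on hand bears on what lies behind either step.

Within the data shown here, with only one group of each kind, it remains open whether the primary amine or the piperidine ring itself sets the number, which a plain piperidin-1-yl or a 4-hydroxypiperidin-1-yl would help to separate. On these data alone, the part played by the chlorine in (5-chloropyridin-3-yl)oxy is also open, and a pyridin-3-yloxy or a plain phenoxy would test it.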